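Amine substituent notes: compound 3 to compound 4

The source may report more compounds than this note shows. Statements on the series, on what has been measured and on what is new or still open speak of the compounds shown alone.

- compound 1 `Fc1ccc(Nc2nc(-c3cccc(F)c3)nc3ccc(F)cc23)cc1`: > 50000 nM (a limit)
- compound 2 `Fc1cccc(-c2nc(Nc3ccc(Br)cc3)c3cc(F)ccc3n2)c1`: > 50000 nM (a limit)
- compound 3 `Oc1ccccc1Nc1nc(-c2cccc(F)c2)nc2ccc(F)cc12`: 44400 nM

For the measured compounds named here, in a functional assay on HL-60 cells (Homo sapiens) for cytotoxicity, read by MTT assay, with a stated time of 48 h (a higher number here means a weaker inhibitor, a lower number a stronger inhibitor), compound 3 gives the only actual number, 44400 nM. Compound 1 and compound 2 both sit at the limit of > 50000 nM in this assay, at which 2 of the 3 values shown sit.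

Compound 4 `Cc1ccc(Nc2nc(-c3cccc(F)c3)nc3ccc(F)cc23)cc1` is related to compound 3 by 4-methylphenyl in place of 2-hydroxyphenyl on a nitrogen on an aromatic ring.

Two measured steps change the same place: an at least 1.1-fold lower number from compound 1 to compound 3 (0.05 log units; that floor lies within the scatter) and an at least 1.1-fold lower number from compound 2 to compound 3 (0.05 log units; that floor lies within the scatter). Both are floors only and lie within the scatter, and a step that the two limits leave unreadable from compound 1 to compound 2 adds nothing on size. On these steps, no change beyond the scatter is expected in this assay, so the expected step is a 1.1-fold higher number from compound 3 to compound 4 (0.05 log units; within the scatter). The estimate for compound 4 is 50000 nM, with an expected range of 20000 nM to 100000 nM.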

Compound 4, half-maximal inhibitory concentration: > 50000 nM
Compound 4 was reported as a limit (the forecaster's own chance of this, stated with the estimate: 65%); the middle value lies on the limit itself.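

In this assay compound 4 is reported as a limit, > 50000 nM. Placing 4-methylphenyl for 2-hydroxyphenyl on the nitrogen gives an at least 1.1-fold higher number from compound 3 to compound 4 (0.05 log units; that floor lies within the scatter), a floor that leaves the true size open. The steps from compound 1 and from compound 2 to compound 4 cannot be read, and a methyl group now ends where fluoro and bromo do: the limit of > 50000 nM in this assay, at which 3 of the 4 values shown sit.

From the compounds shown here alone, whether any group on this nitrogen gives a number clearly clear of that limit remains open. A phenyl ring bearing an amine or a carboxylic acid would be a further test of this position.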